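Amide aryl change from chlorophenyl to difluorophenyl

The source may report more compounds than this note shows. Statements on the series, on what has been measured and on what is new or still open speak of the compounds shown alone.

Three amides of the shared core have been measured. Compound 1 `O=C(Nc1cccc(-c2oc3cc(-c4ccc(F)cc4)ccc3c(=O)c2O)c1)c1ccc(F)cc1` gives 14200 nM in a functional assay on HCC1937 cells (Homo sapiens) for antiproliferative activity, read by CCK-8 assay, with a stated time of 72 h; on this read-out higher numbers stand for weaker inhibition and lower numbers for stronger inhibition; compound 2 `COc1ccc(C(=O)Nc2cccc(-c3oc4cc(-c5ccc(F)cc5)ccc4c(=O)c3O)c2)cc1` gives 5490 nM; compound 3 `O=C(Nc1cccc(-c2oc3cc(-c4ccc(F)cc4)ccc3c(=O)c2O)c1)c1ccc(Cl)cc1` gives 4030 nM. Compound 3 holds the lowest number of the three, but its gap to compound 2 is within the scatter, so the two cannot be ordered; only against compound 1 is compound 3 separated, by a 3.5-fold lower number from compound 1 to compound 3 (0.55 log units; beyond the scatter).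

Compound 4 `O=C(Nc1cccc(-c2oc3cc(-c4ccc(F)cc4)ccc3c(=O)c2O)c1)c1ccc(F)cc1F` differs from compound 3 by 2,4-difluorophenyl in place of 4-chlorophenyl on a carbonyl carbon. Going by the values given here, this reverses the chloro-for-fluoro change of a 3.5-fold lower number from compound 1 to compound 3 (0.55 log units; beyond the scatter) and adds a further fluoro on the entering ring, for which no measured step exists. Among the compounds with values here, the one step that bears on it points back toward compound 1, so a rise in the number is expected, tempered by the unmeasured extra fluoro.

Compound 4 is therefore expected at 9500 nM, between 3500 nM and 26000 nM, a step of a 2.4-fold higher number from compound 3 to compound 4 (0.37 log units; beyond the scatter) relative to compound 3.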

Compound 4, half-maximal inhibitory concentration: 6980 nM
Beside the measured number, compound 4's estimate is 1.4-fold (0.13 log units) above it; the measured number falls inside the stated range.
By their numbers in this assay, from the lowest: compounds 3, 2 and 4 (each within the scatter of the next); then compound 1.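

With 2,4-difluorophenyl on the carbonyl carbon, compound 4 cannot be told apart in this assay from the 4-chlorophenyl amide (a 1.7-fold higher number from compound 3 to compound 4 (0.24 log units; within the scatter)) or the 4-methoxyphenyl amide (a 1.3-fold higher number from compound 2 to compound 4 (0.10 log units; within the scatter)), so compounds 2, 3 and 4 now form one group that this read-out does not order. Going by these compounds alone, the added fluoro gives the first step at this ring that adds a substituent rather than exchanging one, and it separates the pair, though modestly (a 2.0-fold lower number from compound 1 to compound 4 (0.31 log units; beyond the scatter)), leaving compound 1 as the only amide apart from the other three. No measurement at hand accounts for these steps.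

All four amides keep a substituted phenyl ring on the carbonyl carbon. Going by these compounds, what an amine or a carboxylic acid on that ring, or a longer chain in its place, would do to the number remains open.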